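A few compounds are considered here, and "the series" means these few. Any claim that something is new, unique, unknown or untested is made for them only; others in the source may bear on it.

Working notes on the series. Among the compounds with values here, compound 1 `C/C=C(\NC(C)=O)C(=O)N1CCC[C@H]1C(=O)NN(CC(N)=O)C(=O)/C=C/C(=O)OCC` gives 141 nM in an assay on isolated protein for inhibition of legumain (Mus musculus), read by fluorescence, with stated times of 30 s and 2.5 h (a higher number here means a weaker inhibitor, a lower number a stronger inhibitor), the higher of the two numbers measured so far; compound 2 `CCOC(=O)C1OC1C(=O)N(CC(N)=O)NC(=O)[C@@H]1CCCN1C(=O)[C@H](CC)NC(C)=O` gives 8.1 nM, a gap beyond the usual scatter. Within the data shown here, no step between compounds differing in one place is available. Compound 3 `CCOC(=O)/C=C/C(=O)N(CC(N)=O)NC(=O)[C@@H]1CCCN1C(=O)c1cccc(NC(C)=O)c1` differs from compound 1 by a group of 10 heavy atoms (8 carbon, 1 nitrogen, 1 oxygen; one six-membered aromatic ring of carbon only) in place of a group of 7 heavy atoms (5 carbon, 1 nitrogen, 1 oxygen; no ring), on a carbonyl carbon. Among the measured compounds shown here, with no comparable step to lean on, the change from compound 1 to compound 3 is expected to be small, within or only slightly beyond the scatter, at a 1.8-fold higher number from compound 1 to compound 3 (0.25 log units; within the scatter). Compound 3 is therefore estimated at 250 nM, with a range of 60 nM to 1000 nM.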

Compound 3, half-maximal inhibitory concentration: > 1000 nM
Compound 3 gave a limit, no number (the forecaster's own chance of this, stated with the estimate: 5%); middle value at least 4.0-fold (0.60 log units) away from the limit.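

In this assay, putting 3-acetamidophenyl on this carbonyl carbon, in place of the group without a ring, gives an at least 7.0-fold higher number from compound 1 to compound 3 (0.85 log units; beyond the scatter), so this position is not indifferent to the group it carries. For compound 3, > 1000 nM is a limit and not a number. The step is therefore a minimum, and its full size cannot be read: the limit of > 1000 nM in this assay, at which 1 of the 3 values shown sits.

As far as these compounds go, what a plain phenyl or a cyclohexyl group would give on this carbonyl carbon stays open. The contribution of the ring therefore cannot be separated from that of the acetamido substituent.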